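The source may report more compounds than this note shows. Statements on the series, on what has been measured and on what is new or still open speak of the compounds shown alone.

Measured in a functional assay on Jurkat cells (Homo sapiens); a higher number here means a weaker inhibitor, a lower number a stronger inhibitor:
Compound 1 `CC(C)[C@H](NC(=O)COc1cccc2ccccc12)C(=O)N[C@@H](CC(=O)O)C(=O)COc1ccc2ccccc2c1`: > 100000 nM, a limit
Compound 2 `CC(=O)Nc1cccc(OCC(=O)[C@H](CC(=O)O)NC(=O)[C@@H](NC(=O)COc2cccc3ccccc23)C(C)C)c1`: > 100000 nM, a limit
Compound 3 `CC(C)[C@H](NC(=O)COc1cccc2ccccc12)C(=O)N[C@@H](CC(=O)O)C(=O)COc1ccc([N+](=O)[O-])cc1`: > 100000 nM, a limit

Compound 3 has no numerical value on this read-out, only a limit. It shares that position with the other two compounds, as the data show (the limit of > 100000 nM in this assay, at which 3 of the 3 values shown sit).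

Compound 4 `CC(C)[C@H](NC(=O)COc1cccc2ccccc12)C(=O)N[C@@H](CC(=O)O)C(=O)COc1cccc(F)c1` keeps the shared core and changes only the aryl group of the aryloxymethyl end: 3-fluorophenyl in place of 4-nitrophenyl on an oxygen on a saturated carbon. Put simply, 3-fluorophenyl stands in place of 4-nitrophenyl on an oxygen on a saturated carbon.

Among the measured compounds shown here, three measured steps concern this same place. For the measured compounds named here, the first is a step that the two limits leave unreadable from compound 1 to compound 3. The second is a step that the two limits leave unreadable from compound 2 to compound 3. The third is a step that the two limits leave unreadable from compound 1 to compound 2. None of them has a readable size, so together they give no direction and no magnitude for the new exchange. All that carries over is that three different groups at this place left this assay at its limit. The most likely expectation is therefore that compound 4 also stays near that limit, with a real chance that only a limit is reported.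

The estimated change is an at least 1.2-fold lower number from compound 3 to compound 4 (0.09 log units; that floor lies within the scatter), and it is no more than a loose expectation. For compound 4 the expected value is 80000 nM, with an estimated range of 10000 nM to 150000 nM.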

Compound 4, half-maximal inhibitory concentration: > 100000 nM
Compound 4 gave a limit, no number; the forecaster's own chance of this, stated with the estimate: 60%; middle value at least 1.2-fold (0.09 log units) away from the limit.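

In this assay compound 4 gives > 100000 nM, a limit and not a number. Its steps to compound 1, compound 2 and compound 3 cannot be read, and all four compounds sit at the same position: the limit of > 100000 nM in this assay, at which 4 of the 4 values shown sit.

The compounds shown leave open how strongly any of them inhibits in this assay, and whether the aryl group on the oxygen affects that value at all.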